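Removing the chloro group from a weak inhibitor

The compounds below may be only part of what the source reports. "The series", "measured", "known", "first", "only" and "open" are said of these compounds alone.

In a functional assay on a subcellular fraction from brain (Rattus norvegicus) for inhibition, read by scintillation counting, with a stated time of 5 min (on this read-out higher numbers stand for weaker inhibition and lower numbers for stronger inhibition), compound 2 `Cc1ccc(NC2=NCCC3(CCCCC3)S2)cc1Cl` gives 89100 nM. Compound 1 `CC(=O)c1ccc(NC2=NCCC3(CCCCC3)S2)cc1` gives 81300 nM in this assay, a number that lies within the usual scatter of that of compound 2, so the two cannot be ranked. Compound 3 `Cc1ccc(NC2=NCCC3(CCCCC3)S2)cc1` is not yet measured; it differs from compound 2 by hydrogen in place of chloro on an aromatic carbon. Within the data shown here, no measured pair shows what this change does here. Compound 3 is expected to give 100000 nM, somewhere between 40000 nM and 250000 nM, in this assay. The step expected is a 1.1-fold higher number from compound 2 to compound 3 (0.05 log units; within the scatter), not beyond the scatter.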

Compound 3, half-maximal inhibitory concentration in the brain assay: 31600 nM
Compound 3: the middle estimate sits 3.2-fold (0.50 log units) above what was measured, and the stated range ends above it.
By their numbers in the brain assay, from the lowest: compound 3; then compounds 1 and 2 (each within the scatter of the next).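

Chloro on this aromatic carbon therefore costs inhibition rather than adding to it: in the brain assay, hydrogen in its place gives a 2.8-fold lower number from compound 2 to compound 3 (0.45 log units; beyond the scatter). Methyl in place of acetyl on an aromatic carbon gives a 2.6-fold lower number from compound 1 to compound 3 (0.41 log units; beyond the scatter), so the single methyl group of compound 3 outperforms both substituted neighbours. In a physicochemical assay for permeability (a higher number here means that the compound crosses the layer faster, a lower number that the compound crosses the layer more slowly), compound 2 gives 23.9 10^-6 cm/s and compound 3 gives 5.67 10^-6 cm/s, so the better inhibitor of this pair is the one that crosses more slowly.

As far as these compounds go, it remains open whether a fluoro or methoxy group at this place would combine the stronger inhibition of compound 3 with the faster crossing of compound 2.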